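The source may hold more compounds than are shown below. What is called first, only, known or untested is meant among the compounds shown, and "the series" means these compounds.

Working notes on the series. In an in vitro ADME assay on microsomes from liver (Homo sapiens) for metabolic stability (a higher number here means faster removal of the compound, a lower number slower removal), compound 3 (`Nc1nc(C(F)(F)F)cc2c1[nH]c(=O)n2Cc1ccc(C(F)(F)F)nc1`) reports only a limit, < 7 mL.min-1.g-1, so it has no exact place on the scale. Compound 1 (`Cc1cccc(Cn2c(=O)[nH]c3c(N)nc(C(F)(F)F)cc32)n1`) also reports only a limit, < 8 mL.min-1.g-1. Compound 2 (`Cc1nc(Cn2c(=O)[nH]c3c(N)nc(C(F)(F)F)cc32)cs1`) likewise reports only a limit, < 7 mL.min-1.g-1. Among the compounds with values here, no measured compound in this set therefore gives a readable number.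

Compound 4 (`Nc1ccc(Cn2c(=O)[nH]c3c(N)nc(C(F)(F)F)cc32)cn1`) carries amino in place of trifluoromethyl on an aromatic carbon, next to the ring nitrogen and para to a large group: amino in place of trifluoromethyl on an aromatic carbon.

Within the data shown here, the only measured step is a step that the two limits leave unreadable from compound 1 to compound 2. It gives no size to carry over, and it does not involve the trifluoromethyl or amino groups, so it bears on this change only as a further pair of limits. Among the measured compounds shown here, no measured step covers this replacement directly. The working expectation starts from compound 3 and its limit of < 7 mL.min-1.g-1. The expected change in this assay, a number no lower from compound 3 to compound 4 (the limit leaves the size open), is none beyond the scatter, with no direction assigned, and the result may well be another limit. For compound 4 the estimated value is 7 mL.min-1.g-1, with an expected range of 4 mL.min-1.g-1 to 14 mL.min-1.g-1.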

Compound 4, intrinsic clearance in microsomes: < 7 mL.min-1.g-1
Compound 4 was reported as a limit; the forecaster's own chance of this, stated with the estimate: 65%; the middle value sits exactly at the limit.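

In this assay compound 4 reports only a limit, < 7 mL.min-1.g-1. The steps to compound 4 from compound 1, compound 2 and compound 3 therefore cannot be read. The compounds shown leave open where any of the four sits on the scale, and whether amino in place of trifluoromethyl shifts the clearance at all.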